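The source may hold more compounds than are shown below. What is called first, only, known or untested is meant among the compounds shown, and "the series" means these compounds.

Series notes on the solubility set. Compound 1 `CC[C@H]1OC(=O)[C@H](C)[C@@H](O[C@H]2C[C@@](C)(OC)[C@@H](O)[C@H](C)O2)[C@H](C)[C@@H](O[C@@H]2O[C@H](C)C[C@H](N(C)C)[C@H]2OCCCNc2ccnc3cc(Cl)ccc23)[C@](C)(O)C[C@@H](C)CN(C)[C@H](C)[C@@H](O)[C@]1(C)O` carries the 5-hydroxy-4-methoxy-4,6-dimethyloxan-2-yl group. In a physicochemical assay for solubility, at pH 4 (a higher number here means a more soluble compound, a lower number a less soluble compound), compound 1 reaches only a limit of the assay, > 10000 ug/mL. Compound 2 `CC[C@H]1OC(=O)[C@H](C)[C@@H](O)[C@H](C)[C@@H](O[C@@H]2O[C@H](C)C[C@H](N(C)C)[C@H]2OCCCNc2ccnc3cc(Cl)ccc23)[C@](C)(O)C[C@@H](C)CN(C)[C@H](C)[C@@H](O)[C@]1(C)O` differs from compound 1 by hydrogen in place of 5-hydroxy-4-methoxy-4,6-dimethyloxan-2-yl on an oxygen on a saturated carbon. In this assay compound 2 likewise returns a limit, > 10000 ug/mL. With both ends sitting at limits, the step that the two limits leave unreadable from compound 1 to compound 2 is not readable in size. Compound 3 `CC[C@H]1OC(=O)[C@H](C)[C@@H](O[C@H]2C[C@@](C)(OC)[C@@H](O)[C@H](C)O2)[C@H](C)[C@@H](O[C@@H]2O[C@H](C)C[C@H](N(C)C)[C@H]2OCCCN(C)Cc2cnc3ccccc3c2)[C@](C)(O)C[C@@H](C)CN(C)[C@H](C)[C@@H](O)[C@]1(C)O` is built on a different core; how its core differs from that of compound 1 is not broken down here. In this assay compound 3 again gives a limit, > 10000 ug/mL. Compound 4 `CC[C@H]1OC(=O)[C@H](C)[C@@H](O)[C@H](C)[C@@H](O[C@@H]2O[C@H](C)C[C@H](N(C)C)[C@H]2OCCCN(C)Cc2cnc3ccccc3c2)[C@](C)(O)C[C@@H](C)CN(C)[C@H](C)[C@@H](O)[C@]1(C)O` is the unmeasured partner, obtained from compound 3 by hydrogen in place of 5-hydroxy-4-methoxy-4,6-dimethyloxan-2-yl on an oxygen on a saturated carbon, the same change in the same place as from compound 1 to compound 2. For this assay the step of a number no higher from compound 3 to compound 4 (the limit leaves the size open) is expected to be as unreadable as the earlier one, an expectation resting on (the limit of > 10000 ug/mL in this assay, at which 3 of the 3 values shown sit). Compound 4 is therefore estimated at 10000 ug/mL, most likely reported as a limit only.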

Compound 4, solubility: > 10000 ug/mL
Compound 4: no number, only a limit; the forecaster's own chance of this, stated with the estimate: 85%; the middle value lies on the limit itself.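

No new step can be read: in this assay, compound 3 and compound 4 both return only a limit, so the exchange of 5-hydroxy-4-methoxy-4,6-dimethyloxan-2-yl for hydrogen has no readable size. The compounds shown leave open where all four values actually lie, and so how large this change is on either core: the limit of > 10000 ug/mL in this assay, at which 4 of the 4 values shown sit.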